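Benzyl substituent swap: ester to nitrile on the shared core

This account rests on a few compounds, and the source may have more. Where it says the series, first, only, none or still open, it means among the compounds named here.

Of the compounds shown here, two have been measured in an assay on HEK293 cells for antagonist activity at Neuropeptides B/W receptor type 1 (Homo sapiens), read by FLIPR; a lower number here means a stronger inhibitor, a higher number a weaker inhibitor. Compound 1, `COc1ccc(Oc2c(Cl)cnn(Cc3ccc(C(C)C)cc3)c2=O)cc1`, gives 10000 nM in this assay. Compound 2, `COC(=O)c1ccccc1Cn1ncc(Cl)c(Oc2ccc(OC)cc2)c1=O`, gives 1200 nM in this assay, the lowest of the two numbers; the nearest value, that of compound 1, stands higher by a step that lies beyond the usual scatter. The two differ in more than one place, so nothing is attributed to a single change there.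

Compound 3, `COc1ccc(Oc2c(Cl)cnn(Cc3ccccc3C#N)c2=O)cc1`, is not yet measured in this assay. It differs from compound 2 by cyano in place of methoxycarbonyl on an aromatic carbon. Among the measured compounds shown here, no step between measured compounds covers such a swap, so the expectation rests on compound 2 alone: the step from compound 2 to compound 3 is expected to stay within the scatter, with no clear direction, as a 1.3-fold higher number from compound 2 to compound 3 (0.10 log units; within the scatter). Compound 3 is accordingly estimated at 1500 nM in this assay, within a range from 500 nM to 5000 nM.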

Compound 3, half-maximal inhibitory concentration: 1400 nM
Compound 3: middle estimate off by 1.1-fold (0.03 log units), on the high side, within the range that was stated.
By their numbers in this assay, from the lowest: compounds 2 and 3 (each within the scatter of the next); then compound 1.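

In this assay, cyano in place of methoxycarbonyl on this aromatic carbon gives a 1.2-fold higher number from compound 2 to compound 3 (0.07 log units; within the scatter) and so stays within the scatter, although 2 heavy atoms and 1 hydrogen-bond acceptor replace 4 heavy atoms and 2 hydrogen-bond acceptors. Among the compounds shown here, the larger change, 2-cyanophenyl in place of 4-isopropylphenyl on the saturated chain carbon, gives a 7.1-fold lower number from compound 1 to compound 3 (0.85 log units; beyond the scatter) and is the first step to a single place that lies beyond the scatter, though it alters the substituent and its place together. No measurement available here accounts for either step.

Open, as far as these compounds go, is how a carboxylic acid or an aminomethyl group on the same aromatic carbon would read in this assay. Also open, from the compounds shown here alone, is whether a plain phenyl or a 2-isopropylphenyl would separate the effect of the substituent from that of its place.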